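The compounds below may be only part of what the source reports. "The series", "measured", "known", "first", "only" and "open" are said of these compounds alone.

Measured compounds:
Compound 1 `COC(=O)c1ccc(N(C)CC2Cc3c(N)nc(N)nc3NC2=O)cc1`: > 20 ug/mL
Compound 2 `COC(=O)c1ccc(NCC2Cc3c(N)nc(N)nc3NC2=O)cc1`: > 20 ug/mL

In a functional assay on CCRF-CEM cells (Homo sapiens) for inhibition (on this read-out lower numbers stand for stronger inhibition and higher numbers for weaker inhibition), compound 1 gives > 20 ug/mL, which is a limit of the assay rather than a number. Compound 2 gives > 20 ug/mL, again only a limit. Within the data shown here, the single measured step between the two, a step that the two limits leave unreadable from compound 1 to compound 2, is therefore of unknown size, and both values belong to the limit of > 20 ug/mL in this assay, at which 2 of the 2 values shown sit. Nothing in these numbers shows where compound 1 truly stands beyond that limit.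

Compound 3 `CN(CC1Cc2c(N)nc(N)nc2NC1=O)c1ccc(C(=O)O)cc1` differs from compound 1 in one place: hydrogen in place of methyl on an oxygen next to a carbonyl group. This is a different change from the one measured, which concerned the methyl on the aromatic nitrogen, so the measured step does not bear directly on it. With both known values sitting at the same limit, no direction of change can be read from the data.

On this basis compound 3 is expected to give about 30 ug/mL, within a range from 8 ug/mL to 120 ug/mL, with the step from compound 1 estimated as a step that the limit leaves unreadable from compound 1 to compound 3. The measurement will show whether the expected value holds.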

Compound 3, half-maximal inhibitory concentration: > 20 ug/mL
Compound 3 was reported as a limit; the forecaster's own chance of this, stated with the estimate: 70%; the middle value is on the limit's open side.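

In this assay compound 3 gives > 20 ug/mL as a limit and not a number. The step from compound 1 to compound 3 therefore cannot be read, and the three compounds share one limit: the limit of > 20 ug/mL in this assay, at which 3 of the 3 values shown sit. The compounds shown leave open how strongly any of them inhibits, and whether changing methoxycarbonyl to carboxy alters that at all.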